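Swapping bromo for butyl on the carbamate aryl ring

This account rests on a few compounds, and the source may have more. Where it says the series, first, only, none or still open, it means among the compounds named here.

Measured in a functional assay on RAW264.7 cells (Mus musculus) for inhibition, with a stated time of 30 min; on this read-out higher numbers stand for weaker inhibition and lower numbers for stronger inhibition:
Compound 1 `C=C1C(=O)OC[C@H]1CCOC(=O)Nc1ccc(C(=O)OCCCC)cc1`: 430 nM
Compound 2 `C=C1C(=O)OC[C@H]1CCOC(=O)Nc1ccc(Br)cc1`: 350 nM
Compound 3 `C=C1C(=O)OC[C@@H]1CCOC(=O)Nc1ccc(Br)cc1`: 720 nM

Among these three, compound 2 and compound 1 lie within the scatter of each other, the change being a 1.2-fold lower number from compound 1 to compound 2 (0.09 log units; within the scatter), while compound 3, which shares its atoms and bonds with compound 2 (the fact that compounds 2 and 3 differ only in the configuration as drawn), shows a 2.1-fold higher number from compound 2 to compound 3 (0.31 log units; beyond the scatter). Compound 4 `C=C1C(=O)OC[C@H]1CCOC(=O)Nc1ccc(CCCC)cc1` differs from compound 2 by butyl in place of bromo on an aromatic carbon. For the measured compounds named here, the only measured step touching the aromatic substituent, the one from compound 1 to compound 2, was within the scatter, so no step beyond the scatter is expected in this assay, in either direction. Compound 4 is therefore expected near 400 nM, with a range from 180 nM to 900 nM. That estimate means a 1.1-fold higher number from compound 2 to compound 4 (0.06 log units; within the scatter).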

Compound 4, half-maximal inhibitory concentration: 620 nM
Compound 4: the middle estimate sits 1.6-fold (0.19 log units) below what was measured, within the range that was stated.
By their numbers in this assay, from the lowest: compounds 2, 1, 4 and 3 (each within the scatter of the next, the first and the last beyond it).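

In this assay, the position para to a large group has now carried bromo, butoxycarbonyl and butyl without any step leaving the scatter: butyl for bromo gives a 1.8-fold higher number from compound 2 to compound 4 (0.25 log units; within the scatter), and butyl for butoxycarbonyl gives a 1.4-fold higher number from compound 1 to compound 4 (0.16 log units; within the scatter). Thus, an all-carbon chain here gives a number within the scatter of both earlier groups. Nothing available bears on the cause of these steps.

The compounds shown leave open whether an amine or a carboxylic acid at this position would produce a step beyond the scatter. Also open, from the compounds shown here alone, is whether butyl would give a similar number in the configuration drawn in compound 3.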